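Working notes: acetyl in place of fluoro

The source may report more compounds than this note shows. Statements on the series, on what has been measured and on what is new or still open speak of the compounds shown alone.

Compound 1 `Cc1ccc(NC(=O)C(=O)NC(c2nc(C)c(CCO)s2)C2CCCCN2)c(F)c1` gives > 78800 nM in an ADME assay on MT2 cells (Homo sapiens) for cytotoxicity, read by XTT assay, with a stated time of 4 days (on this read-out higher numbers stand for lower toxicity in this test and lower numbers for higher toxicity in this test), as a limit of the assay and not a number.

For the measured compounds named here, compound 2 `Cc1nc(C(NC(=O)C(=O)Nc2ccc(F)cc2)C2CCCCN2)sc1CCO` gives 109000 nM in this assay as the only actual number so far. Going by the values given here, the one measured step is a step that the limit leaves unreadable from compound 1 to compound 2 and it rests on the limit of > 78800 nM in this assay, at which 1 of the 2 values shown sits, so it offers no size to carry forward.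

Compound 3 `CC(=O)c1ccc(NC(=O)C(=O)NC(c2nc(C)c(CCO)s2)C2CCCCN2)cc1` differs from compound 2 by acetyl in place of fluoro on an aromatic carbon, para to a large group (acetyl in place of fluoro on an aromatic carbon). Among the compounds with values here, no measured step covers this change, so compound 3 is expected to stay within the scatter of compound 2 in this assay. Within the data shown here, the only anchor is compound 2 at 109000 nM in that test. The expected outcome is a 1.1-fold lower number from compound 2 to compound 3 (0.04 log units; within the scatter) on this read-out. Compound 3 is estimated at 100000 nM (expected range 50000 nM to 200000 nM).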

Compound 3, half-maximal cytotoxic concentration: > 48300 nM
Compound 3 was reported as a limit; the forecaster's own chance of this, stated with the estimate: 40%; the middle value is on the limit's open side.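

Compound 1 and compound 3 both stand at limits and not numbers, so no step among compound 1, compound 2 and compound 3 can be read in this assay: the limit of > 48300 nM in this assay, at which 1 of the 3 values shown sits.

The compounds shown leave open whether acetyl in place of fluoro on an aromatic carbon shifts the value in this assay at all.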